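From Chloro to Trifluoromethyl on a Sulfonyl-Bound Ring

This account rests on a few compounds, and the source may have more. Where it says the series, first, only, none or still open, it means among the compounds named here.

Of the compounds shown here, two sharing one core have been tested so far in a functional assay on MCF7 cells (Homo sapiens) for antiproliferative activity, read by MTT assay, with a stated time of 24 h; a higher number here means a weaker inhibitor, a lower number a stronger inhibitor. Compound 1 `Cc1ccc(C)c(S(=O)(=O)n2c(-c3cn(-c4ccccc4)nc3-c3ccc(F)cc3)nc3ccccc32)c1` gives 430 nM, while compound 2 `O=S(=O)(c1ccc(Cl)cc1)n1c(-c2cn(-c3ccccc3)nc2-c2ccc(F)cc2)nc2ccccc21` gives 4960 nM, the higher of the two numbers and so the weaker result. Compound 3 `O=S(=O)(c1ccc(C(F)(F)F)cc1)n1c(-c2cn(-c3ccccc3)nc2-c2ccc(F)cc2)nc2ccccc21` has not yet been measured. It differs from compound 2 in one place: trifluoromethyl in place of chloro on an aromatic carbon. Trifluoromethyl takes the place of chloro on an aromatic carbon, which turns 4-chlorophenyl into 4-(trifluoromethyl)phenyl. Within the data shown here, only one measured step bears on this change: a 12-fold higher number from compound 1 to compound 2 (1.06 log units; beyond the scatter). That large step shows that the number can move sharply when the group on the sulfonyl sulfur changes. However, it replaced 2,5-dimethylphenyl with 4-chlorophenyl, a different exchange from this one. Among the measured compounds shown here, no measured pair tests chloro against trifluoromethyl, so the direction remains open, and no step beyond the scatter is expected. The expected change is a 1.2-fold lower number from compound 2 to compound 3 (0.09 log units; within the scatter). For compound 3, the estimated value in this assay is 4000 nM, with an expected range of 1500 nM to 11000 nM.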

Compound 3, half-maximal inhibitory concentration: 1580 nM
Estimate against measurement, compound 3: 2.5-fold (0.40 log units) above; the range from low to high includes it.
By their numbers in this assay, from the lowest: compound 1; then compound 3; then compound 2.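

Swapping a single group on the sulfonyl-bound ring is enough to move the reading in this assay beyond the scatter: trifluoromethyl in place of chloro gives a 3.1-fold lower number from compound 2 to compound 3 (0.50 log units; beyond the scatter) even though neither group counts a hydrogen-bond donor, acceptor, ring or net charge. The exchange recovers only part of the earlier loss, since 2,5-dimethylphenyl still gives the lowest number of the three: going to 4-(trifluoromethyl)phenyl means a 3.7-fold higher number from compound 1 to compound 3 (0.57 log units; beyond the scatter) and stays well short of the larger step to 4-chlorophenyl, which was a 12-fold higher number from compound 1 to compound 2 (1.06 log units; beyond the scatter) in the same assay. No supporting measurement is available to explain why the number shifts with either exchange.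

The compounds shown leave open how this position responds to quite different groups in the same place, such as an amine, a carboxylic acid or a nitrile, which would test whether the change seen here extends beyond chloro and trifluoromethyl. They also leave open whether compound 1 owes its lower number to both of its methyl groups or to just one, which 4-methylphenyl on the sulfonyl sulfur would begin to separate.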